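This account rests on a few compounds, and the source may have more. Where it says the series, first, only, none or still open, it means among the compounds named here.

Compound 1 (`CN1CCN(CC(=O)Nc2ccc3ncnc(Nc4cccc(C(F)(F)F)c4)c3c2)CC1`) gives > 100000 nM as a limit
Compound 2 (`O=C(CN1CCCCC1)Nc1ccc2ncnc(Nc3cccc(Cl)c3)c2c1`) gives > 100000 nM as a limit

Both values come from a functional assay on MCF7 cells (Homo sapiens) for antiproliferative activity, read by MTT assay, with a stated time of 48 h (a lower number here means a stronger inhibitor, a higher number a weaker inhibitor), and neither is a true number. Compound 2 stands at > 100000 nM as a limit, so it offers no exact starting value. All that is known so far is the limit of > 100000 nM in this assay, at which 2 of the 2 values shown sit, and nothing finer. Compound 3 (`CN1CCN(CC(=O)Nc2ccc3ncnc(Nc4cccc(Cl)c4)c3c2)CC1`) shares the core of compound 2, and one group changes (4-methylpiperazin-1-yl in place of piperidin-1-yl on a saturated chain carbon bound to a carbonyl carbon) so that 4-methylpiperazin-1-yl replaces piperidin-1-yl on a saturated chain carbon bound to a carbonyl carbon. Compound 1 also carries 4-methylpiperazin-1-yl and shows > 100000 nM as a limit too. In this assay no step beyond the usual scatter is expected, and compound 3 may well report only a limit. The estimated change (a number no higher from compound 2 to compound 3 (the limit leaves the size open)) is accordingly small. Compound 3 is expected near 100000 nM in an estimated range from 40000 nM to 200000 nM for this measurement.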

Compound 3, half-maximal inhibitory concentration: > 100000 nM
Compound 3: only a limit was reported (the forecaster's own chance of this, stated with the estimate: 70%); the middle value sits exactly at the limit.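

Compound 3 is reported only as a limit, like compound 1 and compound 2, so no step to compound 3 from either of them can be read in this assay: the limit of > 100000 nM in this assay, at which 3 of the 3 values shown sit.

The compounds shown leave open whether 4-methylpiperazin-1-yl in place of piperidin-1-yl, or chloro in place of trifluoromethyl, changes the activity at all.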